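Series notes: compound 3 to compound 4, methoxy removed

This account rests on a few compounds, and the source may have more. Where it says the series, first, only, none or still open, it means among the compounds named here.

Measured so far in a functional assay on A-375 cells (Homo sapiens) for antiproliferative activity, read by MTT assay, with a stated time of 24 h, tested at 3.7 ug/mL; a higher number here means a stronger effect of the compound at the concentration tested, a lower number a weaker effect:
- compound 1 `Cc1c(C(=O)Nc2c(F)cc(-c3cccc(F)c3)cc2F)nc2ccc(F)cc2c1O` gives 7.85%
- compound 2 `CCOc1ccc2nc(C(=O)Nc3c(F)cc(-c4cccc(F)c4)cc3F)c(C)c(O)c2c1` gives 4.56%
- compound 3 `COc1ccc2nc(C(=O)Nc3ccc(-c4ccccc4)cc3)c(C)c(O)c2c1` gives 27.2%

Compound 3 stands highest of the three numbers in this assay. Its nearest neighbour is compound 1, whose number is lower by a gap beyond the scatter; its furthest is compound 2, lower by a larger gap, also beyond the scatter. Going by the values given here, the only single-point step among the measured compounds is a number 3.3 percentage points lower from compound 1 to compound 2 (within the scatter), a change that stays within the scatter.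

Compound 4 `Cc1c(C(=O)Nc2ccc(-c3ccccc3)cc2)nc2ccccc2c1O` differs from compound 3 in one place: hydrogen in place of methoxy on an aromatic carbon. Among the compounds with values here, no measured pair exchanges methoxy for hydrogen at that place, so the step is not covered directly. The step from compound 1 to compound 2 is the only one on the same aromatic carbon, and it exchanges fluoro for ethoxy rather than methoxy for hydrogen, so it bears on the question only loosely; its size was within the scatter. On that basis a small downward step, or none beyond the scatter, is expected, a number 7.2 percentage points lower from compound 3 to compound 4 (within the scatter). Compound 4 is therefore estimated at 20%, with a range from 8% to 32%.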

Compound 4, a percentage reported as inhibition, at one concentration (the size of the read-out at that concentration, not a potency): 17.3%
For compound 4 the middle estimate is 2.7 percentage points above the measured one; measured number inside the range.
By their numbers in this assay, from the lowest: compounds 2, 1, 4 and 3 (each within the scatter of the next, the first and the last beyond it).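

In this assay, going by these compounds alone, the exchange of methoxy for hydrogen on this aromatic carbon gives a number 9.9 percentage points lower from compound 3 to compound 4 (within the scatter) and so provides the first direct reading of that exchange, with no effect that can be told from the scatter. The earlier step at the same carbon, a number 3.3 percentage points lower from compound 1 to compound 2 (within the scatter) on a different amide side, exchanged fluoro for ethoxy, so two different exchanges at this place, on two different amide sides, now stay within the scatter. Within these two pairs, the group on this carbon does not separate the compounds at the single concentration tested, and compound 4 shows that the read-out stays within the scatter of compound 3 with no substituent there beyond hydrogen.

Still open, going by these compounds, is whether an amine or a carboxylic acid on this carbon would shift the read-out beyond the scatter, and whether the exchange of methoxy for hydrogen behaves the same way on the amide side of compound 1. No measurement shown gives a reason for the size of either step.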